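A few compounds are considered here, and "the series" means these few. Any claim that something is new, unique, unknown or untested is made for them only; others in the source may bear on it.

In a physicochemical assay for lipophilicity, using the shake flask method, measured as octanol-water partition, at pH 7.4 (a lower number here means a more polar compound, a higher number a more lipophilic compound), compound 1 `CC(C)n1nc(-c2ccnc3[nH]c(C4CCN(CC(=O)N(C)C)CC4)cc23)ccc1=O` gives 2, the second highest of the three numbers shown. Compound 2 `CC(C)n1cc(-c2ccnc3[nH]c(C4CCN(CC(=O)N5CCCC5)CC4)cc23)ccc1=O` gives 2.1 in this assay, a value within the scatter of compound 1. Compound 3 `COc1cc(C(=O)N2CCCC2)ccc1-c1ccnc2[nH]c(C3CCNCC3)cc12`, which carries an unsubstituted piperidine and an amide-bearing aryl group, gives 0.1, far lower than either of the other two. Compound 4 `COc1cc(=O)n(C)cc1-c1ccnc2[nH]c(C3CCN(CC(=O)N(C)C)CC3)cc12` differs from compound 1 by a group of 10 heavy atoms (7 carbon, 1 nitrogen, 2 oxygen; one six-membered aromatic ring with 1 hetero atom) in place of a group of 10 heavy atoms (7 carbon, 2 nitrogen, 1 oxygen; one six-membered aromatic ring with 2 hetero atoms), on an aromatic carbon. The group that leaves carries an isopropyl chain; the group that enters carries a methoxy and a methyl. Without a measured step of this kind on record, the expected step from compound 1 to compound 4 is estimated at a number 0.50 log units lower from compound 1 to compound 4 (beyond the scatter), a modest drop. Compound 4 is therefore expected to give about 1.5 in this assay, between 0.9 and 2.1.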

Compound 4, distribution coefficient: 0.7
Compound 4: the middle estimate sits 0.80 log units above what was measured; the measured number lies below the stated range.
By their numbers in this assay, from the lowest: compound 3; then compound 4; then compounds 1 and 2 (each within the scatter of the next).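

In this assay, putting the group with a methoxy and a methyl in place of the group with an isopropyl chain, on the aromatic carbon opposite the ring nitrogen, gives a number 1.30 log units lower from compound 1 to compound 4 (beyond the scatter). The heavy-atom count and the hydrogen-bond donor and acceptor counts of the two groups are the same, yet the step at this place is large. Nothing measured here gives a reason for this step. The compounds shown do not separate the contributions of the isopropyl chain, the methoxy, the methyl and the second ring nitrogen. From the compounds shown here alone, how an ethyl chain or a chlorine at this place would read remains open.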